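A few compounds are considered here, and "the series" means these few. Any claim that something is new, unique, unknown or untested is made for them only; others in the source may bear on it.

Compound 1 `COc1cc(OC)c(OC)cc1/C=C/COC(=O)/C=C/c1ccc(OC)c(OC)c1` and compound 2 `COc1cccc(/C=C/C(=O)OC/C=C/c2cc(OC)c(OC)cc2OC)c1` share one core and differ in a single place, hydrogen in place of methoxy on an aromatic carbon. In a functional assay on the whole organism (strain Kunming) with Mus musculus as the target, with a stated time of 0.5 h, at a dose of 300 mg/kg by the intraperitoneal route (a lower number here means a stronger effect, a higher number a weaker effect of the compound at the dose given), compound 1 gives 100%. In this assay compound 2 gives 100%, so compound 2 stands level with compound 1 at the digits shown; the step of no change at the digits printed from compound 1 to compound 2 (within the scatter) lies within the scatter. Compound 3 `COc1ccc(/C=C/C(=O)OC/C=C/c2cc(OC)c(OC)cc2OC)cc1` has not yet been measured. It differs from compound 2 by 4-methoxyphenyl in place of 3-methoxyphenyl on a double-bonded chain carbon bound to a double-bonded chain carbon. For the measured compounds named here, the only measured step that bears on this change is no change at the digits printed from compound 1 to compound 2 (within the scatter), which touched the same aromatic ring and left the read-out unchanged, so no step beyond the scatter is expected for compound 3 in this assay. The expected step of no change at the digits printed from compound 2 to compound 3 (within the scatter) is accordingly close to nil. Compound 3 is estimated to give 100% in this assay, with a range from 85% to 100%.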

Compound 3, a percentage reported as activity, at one dose (the size of the read-out at that dose, not a potency): 100%
Compound 3: the middle estimate sits on the measured number at the digits printed, and the stated range covers the measured number.
By their numbers in this assay, from the lowest: compounds 1, 2 and 3 (each within the scatter of the next).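

In this assay, 4-methoxyphenyl in place of 3-methoxyphenyl on a double-bonded chain carbon bound to a double-bonded chain carbon reads as no change at the digits printed from compound 2 to compound 3 (within the scatter), so the two isomers with a single methoxy on this ring cannot be told apart. Hydrogen in place of methoxy on an aromatic carbon, this time with the other methoxy of that ring removed, reads as no change at the digits printed from compound 1 to compound 3 (within the scatter), so neither methoxy of the ring in compound 1 shows a contribution to the read-out when lost singly. No measurement on hand addresses what lies behind this flat result.

Still open, as far as these compounds go, is whether a different group on this ring, such as an amine or a carboxylic acid, would move the read-out. The compounds shown also leave open whether a ring with no methoxy at all, or a longer chain between the ring and the ester, would separate from compound 1.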